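A few compounds are considered here, and "the series" means these few. Any claim that something is new, unique, unknown or untested is made for them only; others in the source may bear on it.

Working notes on the series, with every reading taken in an in vitro ADME assay on microsomes from liver (Homo sapiens) for metabolic stability; on this read-out higher numbers stand for fast clearance and lower numbers for slow clearance. In this assay compound 1 (`O=C(C=C1CCN(C(=O)c2ccc(F)cc2)CC1)N[C@@H]1CCN(Cc2ccc3cc(F)ccc3c2)C1`) gives 237 mL/min/kg. In the same read-out compound 3 (`COc1cccc(O)c1C(=O)N1CCC(=CC(=O)N[C@@H]2CCN(Cc3ccc4cc(F)ccc4c3)C2)CC1`) gives 192 mL/min/kg, and the two cannot be told apart: a 1.2-fold lower number from compound 1 to compound 3 (0.09 log units; within the scatter). Compound 2 (`O=C(C=C1CCN(C(=O)c2ccccc2O)CC1)N[C@@H]1CCN(Cc2ccc3cc(F)ccc3c2)C1`) gives < 64 mL/min/kg, which is a limit of the assay and not a number. The steps that touch it are larger, an at least 3.7-fold lower number from compound 1 to compound 2 (0.56 log units; beyond the scatter) and an at least 3.0-fold higher number from compound 2 to compound 3 (0.47 log units; beyond the scatter). Compound 3 therefore stands with compound 1, and compound 2 stands apart from both.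

Next in line is compound 4 (`COc1ccc(C(=O)N2CCC(=CC(=O)N[C@@H]3CCN(Cc4ccc5cc(F)ccc5c4)C3)CC2)cc1OC`), which has 3,4-dimethoxyphenyl in place of the 2-hydroxy-6-methoxyphenyl of compound 3 on a carbonyl carbon: 3,4-dimethoxyphenyl in place of 2-hydroxy-6-methoxyphenyl on a carbonyl carbon. Going by the values given here, no measured step makes this exact change, so the aryl steps above serve as the guide. Only compound 2, with its 2-hydroxyphenyl, moved beyond the scatter towards a low number, and compound 4 does not carry that group. Compound 3, which does carry a methoxy group, came back up, an at least 3.0-fold higher number from compound 2 to compound 3 (0.47 log units; beyond the scatter), and compound 1, with no hydroxy group, reads 237 mL/min/kg. No step beyond the scatter is therefore expected, and the estimated change is a 1.0-fold higher number from compound 3 to compound 4 (0.02 log units; within the scatter). For compound 4 the expected value is 200 mL/min/kg, with an estimated range of 110 mL/min/kg to 340 mL/min/kg.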

Compound 4, clearance: 246 mL/min/kg
Estimate against measurement, compound 4: 1.2-fold (0.09 log units) below, within the range that was stated.
By their numbers in this assay, from the lowest: compounds 3, 1 and 4 (each within the scatter of the next). At a limit, below all of these: compound 2.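

In this assay, 3,4-dimethoxyphenyl on this carbonyl carbon, with no hydrogen-bond donor in the group, reads with both 2-hydroxy-6-methoxyphenyl and 4-fluorophenyl: a 1.3-fold higher number from compound 3 to compound 4 (0.11 log units; within the scatter), and a 1.0-fold higher number from compound 1 to compound 4 (0.02 log units; within the scatter). The separation of compound 2 now holds against a third aryl group, an at least 3.8-fold higher number from compound 2 to compound 4 (0.58 log units; beyond the scatter), so among the compounds shown only 2-hydroxyphenyl stands apart, and the hydroxy group alone does not mark the split, since compound 3 carries one and stays with compounds 1 and 4. The reading for compound 2 is a limit of the assay and not a number: the limit of < 64 mL/min/kg in this assay, at which 1 of the 4 values shown sits.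

Going by these compounds alone, how far compound 2 really lies from the other three stays open, as does whether 2-hydroxyphenyl is the only group at this position to stand apart. An amine or a carboxylic acid in place of the hydroxy group, or a longer chain such as ethoxy in place of the methoxy groups, would show whether the split goes beyond this single group.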